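The source may hold more compounds than are shown below. What is called first, only, known or untested is meant among the compounds shown, and "the series" means these compounds.

Of the compounds shown here, three sharing one core have been tested in a functional assay on NCI/ADR-RES cells (Homo sapiens) for inhibition, read by sulforhodamine B assay, with a stated time of 48 h; on this read-out higher numbers stand for weaker inhibition of growth and lower numbers for stronger inhibition of growth. Compound 1 `Nc1cc(N)c2nc(-c3ccccc3)c(NCc3ccc(Cl)c(Cl)c3)nc2c1` gives 45700 nM, and compound 2 `COc1cc(CNc2nc3cc(N)cc(N)c3nc2-c2ccccc2)cc(OC)c1OC` gives 21900 nM. Compound 3 `COc1ccc(Sc2nc3cc(N)cc(N)c3nc2-c2ccccc2)cc1` carries a (4-methoxyphenyl)sulfanyl group in place of the benzylamine-type groups of the other two. Where compound 3 stands is known only as a limit: in this assay compound 3 gives < 100000 nM, which is the limit of the measurement and not a number. This is the limit of < 100000 nM in this assay, at which 1 of the 3 values shown sits, so the reading for compound 3 cannot be placed against compound 1 or compound 2 on a common scale.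

Compound 4 `Nc1cc(N)c2nc(-c3ccccc3)c(Sc3ccc(F)cc3)nc2c1` differs from compound 3 in one spot: fluoro in place of methoxy on an aromatic carbon, a fluoro in place of methoxy on an aromatic carbon, para to a large group. Within the data shown here, no pair of measured compounds shows what such a swap does in this assay, so nothing measured tells the direction or size of the step.

The expectation for compound 4 therefore rests on the spread of the three compounds already seen, with the step from compound 3 to compound 4 estimated as a step that the limit leaves unreadable from compound 3 to compound 4, no firmer than the scatter allows. In this assay compound 4 is expected to give about 40000 nM, with a likely range from 10000 nM to 150000 nM.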

Compound 4, concentration for total growth inhibition: 34700 nM
Estimate against measurement, compound 4: 1.2-fold (0.06 log units) above, and the stated range covers the measured number.
By their numbers in this assay, from the lowest: compounds 2, 4 and 1 (each within the scatter of the next, the first and the last beyond it).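

No step can be read from compound 3 to compound 4, because the reading for compound 3 is a limit and not a number: the limit of < 100000 nM in this assay, at which 1 of the 4 values shown sits.

As far as these compounds go, what fluoro in place of methoxy on an aromatic carbon does in this assay stays open, as does where compound 3 truly stands among the other compounds.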